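Swapping a Bulky Amide Substituent for a Small Amino Group

This account rests on a few compounds, and the source may have more. Where it says the series, first, only, none or still open, it means among the compounds named here.

Of the compounds shown here, three sharing one core have been tested in an assay on isolated protein for inhibition of alkaline phosphatase, tissue-nonspecific isozyme (Homo sapiens); a lower number here means a stronger inhibitor, a higher number a weaker inhibitor. Compound 1 `CC(C)(C)NC(=O)c1cc(-c2ccc(Cl)cc2Cl)n[nH]1` is the weakest of them, giving 398 nM in this assay. Compound 2 `O=C(NCCCO)c1cc(-c2cc(F)c(Cl)cc2Cl)n[nH]1` gives 56 nM, and compound 3 `O=C(NCCO)c1cc(-c2ccc(Cl)c(Cl)c2Cl)n[nH]1` gives 5 nM; both carry a short hydroxyalkyl chain on the amide nitrogen but also differ from compound 1 in their halogen pattern, so no single change can be singled out. Compound 4 `NNC(=O)c1cc(-c2ccc(Cl)cc2Cl)n[nH]1` differs from compound 1 in one place only: amino in place of tert-butyl on an amide-type nitrogen. Within the data shown here, with no directly comparable pair available, the step from compound 1 to compound 4 is expected to be a modest move toward a lower number, a 2.7-fold lower number from compound 1 to compound 4 (0.42 log units; beyond the scatter). Compound 4 is therefore estimated at 150 nM, with a plausible range from 40 nM to 600 nM.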

Compound 4, half-maximal inhibitory concentration: 44 nM
Compound 4: middle estimate off by 3.4-fold (0.53 log units), on the high side; measured number inside the range.
By their numbers in this assay, from the lowest: compound 3; then compounds 4 and 2 (each within the scatter of the next); then compound 1.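

Among these compounds, this is the first pair that differs in one place only, so the change on the amide-type nitrogen can now be read by itself: amino in place of tert-butyl gives a 9.0-fold lower number from compound 1 to compound 4 (0.96 log units; beyond the scatter) in this assay. With the rest of compound 1 unchanged, the tert-butyl group is thus not required for inhibition at this position. No measured evidence accounts for the gain.

A methyl or dimethylamino group on the same nitrogen would help show whether the gain depends on the amino group or on losing tert-butyl. On these data alone, it also remains open whether the step would hold with the halogen patterns of compound 2 and compound 3.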